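The source may report more compounds than this note shows. Statements on the series, on what has been measured and on what is new or still open speak of the compounds shown alone.

Compound 3 `Cc1cc(F)ccc1Nc1ncc(C(F)(F)F)c(N2Cc3cccc(N(C)S(C)(=O)=O)c3C2)n1` stands at the edge of what the assay can report: in a functional assay on A549 cells (Homo sapiens) for antiproliferative activity, read by spectrophotometry, with a stated time of 2 days (on this read-out higher numbers stand for weaker inhibition of growth and lower numbers for stronger inhibition of growth), compound 3 gives > 30000 nM, which is a limit rather than a number. Compound 1 `COc1ccc(C(F)(F)F)cc1Nc1ncc(C(F)(F)F)c(N2Cc3cccc(N(C)S(C)(=O)=O)c3C2)n1` also reaches only a limit in this assay, giving > 30000 nM. Compound 2 `Cc1ccc(Nc2ncc(C(F)(F)F)c(N3Cc4cccc(N(C)S(C)(=O)=O)c4C3)n2)c(Cl)c1` likewise gives > 30000 nM in this assay, again a limit. Among these three, a step that the two limits leave unreadable from compound 1 to compound 2, a step that the two limits leave unreadable from compound 1 to compound 3 and a step that the two limits leave unreadable from compound 2 to compound 3 cannot be sized, since (the limit of > 30000 nM in this assay, at which 3 of the 3 values shown sit). Compound 4 `CN(c1cccc2c1CN(c1nc(Nc3cc(Cl)cc(C(F)(F)F)c3)ncc1C(F)(F)F)C2)S(C)(=O)=O` differs from compound 3 by 3-chloro-5-(trifluoromethyl)phenyl in place of 4-fluoro-2-methylphenyl on a nitrogen on an aromatic ring. No measured step sizes this change, so nothing beyond the scatter is expected. Compound 4 is therefore expected to give 30000 nM, within 8000 nM to 100000 nM, most likely again only a limit, meaning an expected step of a number no higher from compound 3 to compound 4 (the limit leaves the size open).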

Compound 4, concentration for 50% growth inhibition: 6700 nM
The estimate for compound 4 lay 4.5-fold (0.65 log units) above the measured number; measured number outside the range, below it.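

With 3-chloro-5-(trifluoromethyl)phenyl on this nitrogen, the series gives its first readable number, so the group at this position can change growth inhibition: there is an at least 4.4-fold lower number from compound 3 to compound 4 (0.65 log units; beyond the scatter), along with an at least 4.4-fold lower number from compound 2 to compound 4 (0.65 log units; beyond the scatter) and an at least 4.4-fold lower number from compound 1 to compound 4 (0.65 log units; beyond the scatter). These sizes are only minimums, and the full gaps cannot be read: the limit of > 30000 nM in this assay, at which 3 of the 4 values shown sit.

The compounds shown do not separate the contribution of the chlorine from that of the trifluoromethyl group. On these data alone, what an amine or a carboxylic acid on this phenyl ring would do also remains open.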